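Removing One Benzyl Ether from a Weak Sulfide

The source may report more compounds than this note shows. Statements on the series, on what has been measured and on what is new or still open speak of the compounds shown alone.

Measured compounds:
compound 1 `CCOC(=O)C1=C(C)OC2OC(COCc3ccccc3)C(OCc3ccccc3)C(OCc3ccccc3)C2S1` gives 12600 nM in an assay on CHO cells for displacement of a labelled ligand from Substance-K receptor (Homo sapiens); on this read-out lower numbers stand for stronger inhibition and higher numbers for weaker inhibition
compound 2 `CCOC(=O)C1=C(C)OC2OC(COCc3ccccc3)C(OCc3ccccc3)C(OCc3ccccc3)C2[S+]1[O-]` gives 250 nM in this assay

Compound 1 stands at the highest of the two numbers; compound 2 sits far lower, a gap well beyond the scatter. Compound 3 `CCOC(=O)C1=C(C)OC2OC(COCc3ccccc3)C(OCc3ccccc3)C(O)C2S1` carries a single change: hydrogen in place of benzyl on an oxygen on a saturated carbon. Among the compounds with values here, no measured pair shows this kind of change, so its effect is unknown. The author expects a small step from compound 1, in either direction or none beyond the scatter, as given by a 1.2-fold higher number from compound 1 to compound 3 (0.08 log units; within the scatter). Compound 3 is therefore estimated at 15000 nM, with a range from 3000 nM to 60000 nM.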

Compound 3, inhibition constant: 12600 nM
Estimate against measurement, compound 3: 1.2-fold (0.08 log units) above; measured number inside the range.
By their numbers in this assay, from the lowest: compound 2; then compounds 1 and 3 (each within the scatter of the next).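

In this assay, hydrogen in place of benzyl on an oxygen on a saturated carbon gives no change at the digits printed from compound 1 to compound 3 (within the scatter). On the sulfide, then, the read-out does not tell the benzyloxy compound from the hydroxy compound, so this benzyl group makes no visible difference here. Nothing available explains this result.

On these data alone, whether the same change would behave alike on compound 2 remains open. As far as these compounds go, it is also open whether an amine, a carboxylic acid or a longer chain at this position would shift the number.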